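One Aryl Swap, One Expected Number

A few compounds are considered here, and "the series" means these few. Any claim that something is new, unique, unknown or untested is made for them only; others in the source may bear on it.

Measured so far:
Compound 1, `C=CC(=O)Nc1cccc(NC(=O)CSc2nc(Nc3ccccc3F)c3ccccc3n2)c1`: 18700 nM
Compound 2, `C=CC(=O)Nc1cccc(NC(=O)CSc2nc(Nc3ccc(C(F)(F)F)cc3)c3ccccc3n2)c1`: 11500 nM

Both compounds share one core and differ only in the aryl group carried on a nitrogen on an aromatic ring. In a functional assay on MDA-MB-231 cells (Homo sapiens) for inhibition, read by MTT assay, with a stated time of 72 h (a lower number here means a stronger inhibitor, a higher number a weaker inhibitor), compound 1 gives 18700 nM, and compound 2 gives 11500 nM. The step of a 1.6-fold lower number from compound 1 to compound 2 (0.21 log units; within the scatter) is within the scatter, so the two numbers cannot be told apart; compound 2 simply sits beside compound 1 with nothing separating them beyond measurement noise.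

Compound 3, `C=CC(=O)Nc1cccc(NC(=O)CSc2nc(Nc3ccc(Cl)cc3Cl)c3ccccc3n2)c1`, is not yet measured. It differs from compound 2 by 2,4-dichlorophenyl in place of 4-(trifluoromethyl)phenyl on a nitrogen on an aromatic ring. Among the compounds with values here, the only measured step that bears on this change is the one aryl-for-aryl swap already seen, a 1.6-fold lower number from compound 1 to compound 2 (0.21 log units; within the scatter), and it moved the number by an amount within the scatter. With a single step of that kind to go on, compound 3 is expected to land close to compound 2, with no step beyond the scatter in either direction, as the estimate a 1.0-fold higher number from compound 2 to compound 3 (0.02 log units; within the scatter) expresses. Compound 3 is therefore estimated at 12000 nM, with a range from 5000 nM to 30000 nM.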

Compound 3, half-maximal inhibitory concentration: 23100 nM
Beside the measured number, compound 3's estimate is 1.9-fold (0.28 log units) below it; the measured number falls inside the stated range.
By their numbers in this assay, from the lowest: compounds 2, 1 and 3 (each within the scatter of the next).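

In this assay, a third aryl group on the same nitrogen gives a 2.0-fold higher number from compound 2 to compound 3 (0.30 log units; within the scatter) and also a 1.2-fold higher number from compound 1 to compound 3 (0.09 log units; within the scatter) for 2,4-dichlorophenyl in place of the two earlier groups. Where the earlier pair offered only a single comparison, compounds 1, 2 and 3 now form a set of three in which every pairwise step lies within the scatter, so 2-fluorophenyl, 4-(trifluoromethyl)phenyl and 2,4-dichlorophenyl cannot be told apart at this place in this assay, even though the groups differ in their atoms and in where those atoms sit on the ring. Nothing measured here speaks to why the three numbers stay so close.

From the compounds shown here alone, all three groups are phenyl rings carrying fluorine or chlorine, so it remains open whether a phenyl ring bearing an amine or a carboxylic acid would give a number clearly separated from these. Also open, going by these compounds, is what a group without an aromatic ring, such as cyclohexyl or a longer alkyl chain, would do on the same nitrogen.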